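Swapping a benzyl amine for a benzamide at the sigma receptor

This account rests on a few compounds, and the source may have more. Where it says the series, first, only, none or still open, it means among the compounds named here.

Measured compounds:
- compound 1, `CCCn1nc(C(=O)N(C)C)c2c1CCC(NCc1ccc(F)cc1)C2`: 1580 nM
- compound 2, `O=C(c1nn(-c2ccccc2)c2c1CC(NCc1ccc(F)cc1)CC2)N1CCCCC1`: 158 nM

In an assay on HEK293 cells for displacement of a labelled ligand from Sigma non-opioid intracellular receptor 1 (Homo sapiens), read by scintillation counting, with a stated time of 120 min (on this read-out lower numbers stand for stronger inhibition and higher numbers for weaker inhibition), compound 1 gives 1580 nM, the higher of the two numbers shown. Compound 2, which carries a different substituent on the core nitrogen and a different amide, gives 158 nM, a lower number that lies well beyond the scatter of the measurement. The two compounds differ in more than one place, so the gap between them cannot be assigned to any single change.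

Compound 3, `CCCn1nc(C(=O)N(C)C)c2c1CCC(NC(=O)c1ccc(F)cc1)C2`, is not yet measured. It differs from compound 1 in exactly one place: (4-fluorophenyl)carbonyl in place of 4-fluorobenzyl on an amine nitrogen. The amine nitrogen that links the core to the fluorinated ring thus becomes part of an amide. For the measured compounds named here, no measured pair shows the effect of this kind of change, so the expectation rests on the structural change alone.

The step from compound 1 to compound 3 in this assay is expected to be an increase in the number, a 6.3-fold higher number from compound 1 to compound 3 (0.80 log units; beyond the scatter), meaning weaker binding. Compound 3 is therefore estimated at 10000 nM, within a range from 2500 nM to 40000 nM.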

Compound 3, inhibition constant: > 10000 nM
Compound 3: no number, only a limit; the forecaster's own chance of this, stated with the estimate: 30%; the middle value sits exactly at the limit.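

In this assay compound 3 gives > 10000 nM, which is a limit of the assay and not a number. Compound 1 and compound 2 differ in more than one place, but this pair isolates a single change: (4-fluorophenyl)carbonyl in place of 4-fluorobenzyl on an amine nitrogen gives an at least 6.3-fold higher number from compound 1 to compound 3 (0.80 log units; beyond the scatter), so binding at this position is clearly weaker with the amide than with the benzyl amine. The full size of the step cannot be read from these results, and it may be larger than the printed figure: the limit of > 10000 nM in this assay, at which 1 of the 3 values shown sits.

How a sulfonyl group or a 2-(4-fluorophenyl)ethyl chain on this amine nitrogen would read in this assay remains an open question, so it cannot yet be said whether the 4-fluorobenzyl group is unusually well suited to this position or whether the carbonyl form is unusually poor. On these data alone, it is also open whether the same swap on compound 2, with its different substituent on the core nitrogen and its different amide, would weaken binding to a similar extent.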